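This account rests on a few compounds, and the source may have more. Where it says the series, first, only, none or still open, it means among the compounds named here.

Measured so far:
compound 1 `O=C(CCCCC(S)CCS)NO`: "not active" (no number reported)
compound 2 `O=C(CCCCC1CCSS1)Nc1cccc(C(F)(F)F)c1`: 5%
compound 3 `O=C(CCCCC1CCSS1)Nc1ccc([N+](=O)[O-])c(C(F)(F)F)c1`: "not active" (no number reported)

In a functional assay on HO8910 cells (Homo sapiens) for inhibition, read by MTT assay, with a stated time of 24 h, tested at 0.1 ug/mL (a higher number here means more inhibition of growth at the concentration tested, a lower number less inhibition of growth), compound 2 gives 5%. For the measured compounds named here, this is the only number available, since compound 1 and compound 3 were reported without one. Going by the values given here, compound 2 therefore cannot be ranked against a second figure, and no step between two measured compounds is available to serve as a guide.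

The next compound to test is compound 4 `O=C(CCCCC(S)CCS)Nc1cccc(C(F)(F)F)c1`. It keeps the rest of compound 2 and changes one group: a group of 5 heavy atoms (3 carbon, 2 sulfur; no ring) in place of a group of 5 heavy atoms (3 carbon, 2 sulfur; one five-membered non-aromatic ring with 2 hetero atoms), on a saturated chain carbon, four bonds along the chain from a carbonyl carbon. Put simply, the five-membered non-aromatic ring gives way to an open 1,3-disulfanylpropyl group at the same place on the chain.

The evidence on this open group is thin. Compound 1 also carries 1,3-disulfanylpropyl, and it is reported as "not active" (no number reported), so the data offer no sign that the open group raises the read-out. In this assay, no step beyond the usual scatter is expected, and no firm direction can be given. The expected step is a number 2 percentage points higher from compound 2 to compound 4 (within the scatter), which stays within that scatter. The estimate for compound 4 is 7%, with an expected range of 0% to 22%.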

Compound 4, percent growth inhibition at one concentration: 10.8%
Compound 4: the middle estimate sits 3.8 percentage points below what was measured, within the range that was stated.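

In this assay, replacing the five-membered ring with an open 1,3-disulfanylpropyl group gives a number 5.8 percentage points higher from compound 2 to compound 4 (within the scatter) on a saturated chain carbon, four bonds along the chain from a carbonyl carbon, so at this concentration the measured numbers do not separate the ring from the open group. Compound 4 gives 10.8% and compound 1, which carries the same open group, is reported as "not active" (no number reported) in the same test, so having the open group does not guarantee a numerical reading, and steps involving compound 1 or compound 3 cannot be read. Nothing measured here explains why the closed and open forms give readings within the scatter of each other.

Still open, from the compounds shown here alone, is whether a single sulfanyl group, an amine or a carboxylic acid at this place, or a longer chain carrying both sulfur atoms, would move the read-out beyond the scatter. Also open, going by these compounds, is how the open group would read in a compound that also has the nitro group of compound 3.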